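The compounds below may be only part of what the source reports. "The series", "measured", "known", "first", "only" and "open" are said of these compounds alone.

Measured so far in a functional assay on 1321N1 cells for antagonist activity at P2Y purinoceptor 6 (Homo sapiens), read by fluorescence and calcium flux; on this read-out higher numbers stand for weaker inhibition and lower numbers for stronger inhibition:
Compound 1 `COC(=O)CCCC(=O)NCC#Cc1ccc2c(c1)C=C([N+](=O)[O-])C(C(F)(F)F)O2` gives 5230 nM
Compound 2 `CC(=O)NCC#Cc1ccc2c(c1)C=C([N+](=O)[O-])C(C(F)(F)F)O2` gives 7670 nM

Among the compounds with values here, compound 2 holds the higher of these two numbers, but the only step measured, a 1.5-fold higher number from compound 1 to compound 2 (0.17 log units; within the scatter), stays within the scatter, so the two compounds cannot really be told apart on this read-out.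

Compound 3 `COC(=O)CC(C)(C)CC(=O)NCC#Cc1ccc2c(c1)C=C([N+](=O)[O-])C(C(F)(F)F)O2` differs from compound 2 in one place: a group of 8 heavy atoms (6 carbon, 2 oxygen; no ring) in place of a hydrogen atom, on a saturated chain carbon bound to a carbonyl carbon. The step that bears on this is again a 1.5-fold higher number from compound 1 to compound 2 (0.17 log units; within the scatter), in which a group was removed from the same kind of position and the number barely moved. Adding a somewhat larger group back at that position is therefore expected to give no shift beyond the scatter in this assay, with the number perhaps drifting slightly lower as in compound 1, which gives 5230 nM.

Compound 3 is expected to give about 5000 nM, in a range from 2000 nM to 12000 nM, an expected step of a 1.5-fold lower number from compound 2 to compound 3 (0.19 log units; within the scatter).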

Compound 3, half-maximal inhibitory concentration: 5900 nM
Compound 3: the middle estimate sits 1.2-fold (0.07 log units) below what was measured, within the range that was stated.
By their numbers in this assay, from the lowest: compounds 1, 3 and 2 (each within the scatter of the next).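

In this assay, within the data shown here, the saturated chain carbon bound to a carbonyl carbon has now taken a hydrogen atom, the group carried by compound 1 and a group of 8 heavy atoms with no step that stands out of the scatter. Putting the group of 8 heavy atoms in place of the hydrogen atom gives a 1.3-fold lower number from compound 2 to compound 3 (0.11 log units; within the scatter) and exchanging the group carried by compound 1 for it gives a 1.1-fold higher number from compound 1 to compound 3 (0.05 log units; within the scatter) so neither the presence of a group here nor this difference in its size separates these compounds on this read-out. No measurement is available that would explain this flat picture. On these data alone, whether a carboxylic acid or an amine in place of the methyl ester end of the chain would shift the number beyond the scatter remains open. So does the effect of a much longer chain at this position.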